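Amino in place of methoxycarbonyl on compound 3

The compounds below may be only part of what the source reports. "The series", "measured", "known", "first", "only" and "open" are said of these compounds alone.

For the measured compounds named here, in an ADME assay on HepG2 cells (Homo sapiens) for cytotoxicity, with a stated time of 72 h (on this read-out higher numbers stand for an effect only at larger amounts of compound and lower numbers for an effect already at smaller amounts), compound 3 (`COC(=O)c1ccc(NC(=O)Nc2cc(C)nc3ccccc23)cc1`) gives 20000 nM and this is the only number among the three compounds measured so far. Compound 1 (`Cc1cc(NC(=O)Nc2cccc(F)c2)c2ccccc2n1`) gives > 25000 nM in this assay as a limit and not a number. Compound 2 (`Cc1cc(NC(=O)Nc2ccc(N(C)C)cc2)c2ccccc2n1`) gives > 25000 nM in this assay as a limit too. Compound 4 (`Cc1cc(NC(=O)Nc2ccc(N)cc2)c2ccccc2n1`) differs from compound 3 at one place: amino in place of methoxycarbonyl on an aromatic carbon with amino in place of methoxycarbonyl on an aromatic carbon, para to a large group. Going by the values given here, one measured step bears on this change, methoxycarbonyl in place of dimethylamino on an aromatic carbon, which gave an at least 1.2-fold lower number from compound 2 to compound 3 (0.09 log units; that floor lies within the scatter) in this assay as its only measure. The picture rests largely on the limit of > 25000 nM in this assay, at which 2 of the 3 values shown sit, so the size of that step is known only as a floor. Removing the methoxycarbonyl again should therefore move the number little, and no step beyond the scatter is expected, since compound 3 gives 20000 nM with so small a measured step leading to it. The expected step is a 1.2-fold higher number from compound 3 to compound 4 (0.08 log units; within the scatter) in this assay and it may be no more than that. Compound 4 is estimated at 24000 nM with an expected range from 12000 nM to 40000 nM and it may well return only a limit.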

Compound 4, half-maximal effective concentration: > 25000 nM
Compound 4: no number, only a limit; the forecaster's own chance of this, stated with the estimate: 55%; middle value at least 1.0-fold (0.01 log units) away from the limit.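

For the compounds shown here, the exchange at this aromatic carbon, para to a large group, gives in this assay an at least 1.2-fold higher number from compound 3 to compound 4 (0.09 log units; that floor lies within the scatter), so swapping a methoxycarbonyl of 4 heavy atoms for an amino of 1 heavy atom yields no step that can be told from the scatter. Going by these compounds alone, with compound 4 the position now carries a second nitrogen-bearing group that returns only a limit of the assay, as dimethylamino does in compound 2, and methoxycarbonyl in compound 3 remains the only group here with an actual number. The steps from compound 2 and from compound 1 to compound 4 cannot be read, and the step from compound 3 is known only as a floor, because the series sits mostly at one ceiling: the limit of > 25000 nM in this assay, at which 3 of the 4 values shown sit.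

How far compound 2 and compound 4 actually lie past that limit remains open, so the compounds shown do not establish that methoxycarbonyl differs from either nitrogen-bearing group at this position. Going by these compounds, it is also open whether a carboxylic acid or a longer ester chain at the same carbon would give a number, and whether that number would stand beyond the scatter from compound 3.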